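Anilino variation on a shared core: toward compound 4

The source may hold more compounds than are shown below. What is called first, only, known or untested is meant among the compounds shown, and "the series" means these compounds.

Measured so far:
compound 1 `Cc1ccc(NC2=CC(=O)c3c(nc4n3[C@H]3OC[C@@H](O)[C@H]3OC4)C2=O)cc1C` gives 4320 nM in a functional assay on HeLa cells (Homo sapiens) for inhibition, read by sulforhodamine B assay; a lower number here means a stronger inhibitor, a higher number a weaker inhibitor
compound 2 `COc1ccccc1NC1=CC(=O)c2nc3n(c2C1=O)[C@H]1OC[C@@H](O)[C@H]1OC3` gives 2950 nM in this assay
compound 3 `COc1cccc(NC2=CC(=O)c3nc4n(c3C2=O)[C@H]2OC[C@@H](O)[C@H]2OC4)c1` gives 4280 nM in this assay

The three numbers lie close together. Compound 1 sits within the scatter of compound 3 and within the scatter of compound 2, so the three compounds cannot be told apart on these numbers. Within the data shown here, the only single-point step measured, a 1.5-fold higher number from compound 2 to compound 3 (0.16 log units; within the scatter), stays within the scatter as well.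

Compound 4 `O=C1C(Nc2cccc(F)c2)=CC(=O)c2c1nc1n2[C@H]2OC[C@@H](O)[C@H]2OC1` is not yet measured in this assay. It differs from compound 1 in one place: 3-fluorophenyl in place of 3,4-dimethylphenyl on an amine nitrogen. Among the measured compounds shown here, no measured step swaps a dimethylphenyl for a fluorophenyl; the one step on record only moves a methoxy group around its ring. With the three anilino variants so far all falling within the scatter of one another, the expectation for compound 4 is no step beyond the scatter, that is a 1.1-fold lower number from compound 1 to compound 4 (0.03 log units; within the scatter). Compound 4 is therefore estimated at 4000 nM in this assay, with a range from 1500 nM to 12000 nM.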

Compound 4, half-maximal inhibitory concentration: > 8000 nM
Compound 4 gave a limit, no number; the forecaster's own chance of this, stated with the estimate: 10%; at least 2.0-fold (0.30 log units) between middle value and limit.
By their numbers in this assay, from the lowest: compounds 2, 3 and 1 (each within the scatter of the next). At a limit, above all of these: compound 4.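

Compound 4 is reported in this assay as a limit, not a number: the limit of > 8000 nM in this assay, at which 1 of the 4 values shown sits. Exchanging 3,4-dimethylphenyl for 3-fluorophenyl on the amine nitrogen gives an at least 1.8-fold higher number from compound 1 to compound 4 (0.26 log units; that floor lies within the scatter). Among these compounds, compounds 1, 2 and 3 lie within the scatter of one another, whereas compound 4 is the first anilino variant that cannot be given a place among them, so the tolerance of this position to change is no longer settled, although the floor of this step does not by itself set compound 4 apart from compound 1.

Going by these compounds, how far compound 4 actually lies from compound 1 remains open, and so does whether the fluorine or the absence of the two methyl groups matters more. A plain phenyl, a chlorophenyl or a pyridine on the same amine nitrogen could help separate these readings.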